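Moving the methoxy group on the aryl ring of compound 1

This account rests on a few compounds, and the source may have more. Where it says the series, first, only, none or still open, it means among the compounds named here.

In a functional assay on HeLa cells (Homo sapiens) for antiproliferative activity, read by MTT assay, with a stated time of 72 h (a higher number here means a weaker inhibitor, a lower number a stronger inhibitor), compound 1 `COc1ccc(N2C(=O)COc3ccc(-c4ccc(O)cc4)cc32)cc1` gives 16400 nM and compound 2 `COc1ccc(N2C(=O)COc3ccc(-c4cnc(Cl)c(NS(=O)(=O)c5ccc(F)cc5)c4)cc32)cc1` gives 8320 nM, two values within the usual scatter of each other. Compound 3 `COc1cccc(N2C(=O)COc3ccc(-c4ccc(O)cc4)cc32)c1` has the same atoms as compound 1, joined differently: 3-methoxyphenyl in place of 4-methoxyphenyl on an amide-type nitrogen in a ring, with 3-methoxyphenyl in place of 4-methoxyphenyl on an amide-type nitrogen in a ring. Among the measured compounds shown here, no measured pair shows a change of this kind, so no clear direction can be argued. The expected step of a 1.1-fold lower number from compound 1 to compound 3 (0.04 log units; within the scatter) is estimated to stay within the scatter in this assay. Compound 3 is expected at 15000 nM, with an estimated range of 6000 nM to 40000 nM.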

Compound 3, half-maximal inhibitory concentration: > 40000 nM
Compound 3: only a limit was reported (the forecaster's own chance of this, stated with the estimate: 15%); middle value at least 2.6-fold (0.42 log units) away from the limit.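

Among the compounds shown here, on the amide-type nitrogen in a ring, the placement of the methoxy group on the aryl ring makes a difference in this assay: 3-methoxyphenyl in place of 4-methoxyphenyl gives an at least 2.4-fold higher number from compound 1 to compound 3 (0.38 log units; beyond the scatter), the first step here beyond the scatter. Compound 3 gives > 40000 nM, which is a limit and not a number. The size of the step therefore stays bounded on one side only: the limit of > 40000 nM in this assay, at which 1 of the 3 values shown sits. The compounds shown leave open how an amine or a carboxylic acid in place of the methoxy group would fare on this ring. They also leave open whether the same change would act alike on compound 2.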